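Removing the Methoxy Group of Compound 2

The source may hold more compounds than are shown below. What is called first, only, known or untested is meant among the compounds shown, and "the series" means these compounds.

compound 1 `OC(CCn1nc2c(Br)c(Br)c(Br)c(Br)c2n1)c1cccc(Br)c1`: 1%
compound 2 `COc1cccc(C(O)CCn2nc3c(Br)c(Br)c(Br)c(Br)c3n2)c1`: 16%

In a functional assay on MCF7 cells (Homo sapiens) for antiproliferative activity, read by MTT assay, with a stated time of 24 h, tested at 100 uM (on this read-out lower numbers stand for a stronger effect and higher numbers for a weaker effect at the one concentration tested), compound 1 gives 1% and compound 2 gives 16%. Among the measured compounds shown here, compound 2 stands highest of the two numbers, with compound 1 as its only neighbour; the single measured step, a number 15 percentage points higher from compound 1 to compound 2 (beyond the scatter), is modest and beyond the scatter. Compound 3 `OC(CCn1nc2c(Br)c(Br)c(Br)c(Br)c2n1)c1ccccc1` differs from compound 2 by hydrogen in place of methoxy on an aromatic carbon. For the measured compounds named here, no measured step removes a methoxy group, so the one step bears only loosely, showing that a change at this aromatic carbon moved the number modestly. For compound 3 a small downward step is expected, a number 8 percentage points lower from compound 2 to compound 3 (within the scatter). Compound 3 is estimated at 8%, within 0% to 25%.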

Compound 3, a percentage reported as activity, at one concentration (the size of the read-out at that concentration, not a potency): 13%
For compound 3 the middle estimate is 5 percentage points below the measured one; measured number inside the range.
By their numbers in this assay, from the lowest: compound 1; then compounds 3 and 2 (each within the scatter of the next).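

In this assay, hydrogen and methoxy on this aromatic carbon are not told apart, with a number 3 percentage points lower from compound 2 to compound 3 (within the scatter). Bromo is the substituent that stands apart, with a number 12 percentage points higher from compound 1 to compound 3 (beyond the scatter), so the earlier difference between bromo and methoxy now also appears between bromo and hydrogen. No measured evidence here accounts for the separation of bromo from the other two groups.

The compounds shown leave open whether chloro, an amine or a carboxylic acid on this aromatic carbon would give a number close to that of compound 1 or to those of compound 2 and compound 3.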